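Sulfonyl aryl swap and liver microsomal clearance

The source may report more compounds than this note shows. Statements on the series, on what has been measured and on what is new or still open speak of the compounds shown alone.

Measured compounds
compound 1 `O=S(=O)(c1cc(Cl)cc(Cl)c1)c1cnc2cc(F)ccc2c1-c1ccc(Cl)cc1` — 0.13 mL/min
compound 2 `O=S(=O)(c1cccc(F)c1)c1cnc2cc(F)ccc2c1-c1ccc(Cl)cc1` — 0.98 mL/min
compound 3 `O=S(=O)(c1cc(Cl)cc(Cl)c1)c1cnc2c(F)cccc2c1-c1ccccc1F` — 0.44 mL/min

In an ADME assay on microsomes from liver (Homo sapiens) for metabolic stability, tested at 2.5 uM (on this read-out higher numbers stand for fast clearance and lower numbers for slow clearance), compound 1 gives 0.13 mL/min, the lowest number of the three. Compound 2 gives 0.98 mL/min in this assay. The step between them is a 7.5-fold higher number from compound 1 to compound 2 (0.88 log units; beyond the scatter); the change behind it is 3-fluorophenyl in place of 3,5-dichlorophenyl on a sulfonyl sulfur. Compound 3 gives 0.44 mL/min in this assay and stands between the other two, with both gaps beyond the scatter. Compound 3 shares the sulfonyl substituent of compound 1, but how the two cores differ is not broken down here.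

Compound 4 `O=S(=O)(c1cccc(F)c1)c1cnc2c(F)cccc2c1-c1ccccc1F` has not yet been measured in this assay. It differs from compound 3 by 3-fluorophenyl in place of 3,5-dichlorophenyl on a sulfonyl sulfur. The place is described in the same words for both pairs, so this is the same change as that from compound 1 to compound 2, made on a different core.

Compound 4 is expected to show a step of a 6.4-fold higher number from compound 3 to compound 4 (0.80 log units; beyond the scatter) in this assay. For the measured compounds named here, this rests on the single precedent a 7.5-fold higher number from compound 1 to compound 2 (0.88 log units; beyond the scatter). Going by the values given here, the cores of compound 1 and compound 3 are not the same, and only one instance of the change is measured, so the expectation is tempered. Compound 4 is therefore expected to give about 2.8 mL/min in this assay, with a plausible range from 1.1 mL/min to 6.5 mL/min.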

Compound 4, intrinsic clearance in a liver preparation (reported as CLH), per the amount of preparation that the assay uses: 0.21 mL/min
Estimate against measurement, compound 4: 13-fold (1.12 log units) above, and the stated range ends above it.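

In this assay, 3-fluorophenyl in place of 3,5-dichlorophenyl on the sulfonyl sulfur gives a 2.1-fold lower number from compound 3 to compound 4 (0.32 log units; beyond the scatter), so on this core the change runs in the opposite direction to the earlier instance. The two instances therefore differ in direction as well as in size, and the gap between them is larger than repeated measurements would explain: the same change on two cores in this assay, a 7.5-fold higher number (0.88 log units; beyond the scatter) from compound 1 to compound 2 and a 2.1-fold lower number (0.32 log units; beyond the scatter) from compound 3 to compound 4, 16-fold (1.20 log units) apart, beyond the scatter of two such steps. This shows that, in this series, the change cannot be carried from one core to another as a fixed step, but it does not show which of the differences between the core of compound 1 and the core of compound 3 matters, and two instances give no rule for predicting the step on a third core.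

Still open, on these data alone, is how the same change behaves on cores that carry only one of those differences, which would separate the contribution of the fluorine on the fused ring system from that of the aryl group on the core. Also open, as far as these compounds go, is how this assay responds when the sulfonyl aryl group carries an amine or a carboxylic acid instead of halogens.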